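Phenyl in Place of Benzofuranyl on Two Related Cores

The compounds below may be only part of what the source reports. "The series", "measured", "known", "first", "only" and "open" are said of these compounds alone.

Compound 1 `CNc1ncnc2c1c(-c1ccccc1)cn2[C@@H]1O[C@H](CO)[C@@H](O)[C@H]1O`, compound 2 `O=c1[nH]cnc2c1c(-c1cc3ccccc3o1)cn2[C@@H]1O[C@H](CO)[C@@H](O)[C@H]1O` and compound 3 `CNc1ncnc2c1c(-c1cc3ccccc3o1)cn2[C@@H]1O[C@H](CO)[C@@H](O)[C@H]1O` have closely related cores and were tested in a functional assay on CCRF-CEM cells (Homo sapiens), read by MTT assay, with a stated time of 72 h; a higher number here means a weaker inhibitor, a lower number a stronger inhibitor. In this assay compound 1 gives only a limit, > 20000 nM. Compound 2 likewise gives only a limit, > 20000 nM. Compound 3 also gives only a limit, > 20000 nM. The change from compound 3 to compound 1 is phenyl in place of 1-benzofuran-2-yl on an aromatic carbon, and its step that the two limits leave unreadable from compound 3 to compound 1 cannot be read because of the limit of > 20000 nM in this assay, at which 3 of the 3 values shown sit. Compound 4 `O=c1[nH]cnc2c1c(-c1ccccc1)cn2[C@@H]1O[C@H](CO)[C@@H](O)[C@H]1O`, not yet measured, carries the same change on the core of compound 2: phenyl in place of 1-benzofuran-2-yl on an aromatic carbon. The difference between the two cores is not broken down here. With compound 3 and compound 1 both sitting at the limit (the limit of > 20000 nM in this assay, at which 3 of the 3 values shown sit), the expected step is a step that the limit leaves unreadable from compound 2 to compound 4. Compound 4 is therefore expected to give 30000 nM, within a range from 8000 nM to 120000 nM.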

Compound 4, half-maximal inhibitory concentration: > 100000 nM
Compound 4: no number, only a limit; the forecaster's own chance of this, stated with the estimate: 85%; at least 3.3-fold (0.52 log units) between middle value and limit.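

Compound 2 and compound 4 both give only limits, so no step can be read between them. The compounds shown leave open how strongly any of them inhibits in this assay, and therefore what phenyl in place of 1-benzofuran-2-yl changes.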